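The compounds below may be only part of what the source reports. "The series", "measured", "known", "first", "only" and "open" are said of these compounds alone.

Measured in a functional assay on NT2 cells (Homo sapiens) for inhibition; on this read-out lower numbers stand for stronger inhibition and higher numbers for weaker inhibition:
Compound 1 `CCC(C(=O)N[C@@H](CC(=O)O)C(C)=O)n1cc(C(C)(C)C)nc(NCc2nonc2C)c1=O`: 5.12 nM
Compound 2 `CC[C@@H](C(=O)N[C@@H](CC(=O)O)C(=O)CSCc1ccccc1)n1cccc(NC(=O)[C@H](CC(=O)O)NC(C)=O)c1=O`: 5.2 nM
Compound 3 `CCCCCCN(C)CNCC(=O)[C@H](CC(=O)O)NC(=O)C(CC)n1cc(C(C)(CC)CC)nc(NCc2nonc2C)c1=O`: 0.025 nM

Compound 3 has the lowest number of the three, beyond the scatter from both compound 1 and compound 2. Compound 4 `CCCCCCN(C)CNCC(=O)[C@H](CC(=O)O)NC(=O)C(CC)n1cc(CC)nc(NCc2nonc2C)c1=O` has ethyl in place of 1-ethyl-1-methylpropyl on an aromatic carbon. Going by the values given here, no measured pair isolates this swap, as the three measured compounds differ in several places at once. Among the compounds with values here, with compound 3 at 0.025 nM, the lowest number so far, a rise in this assay seems likelier than a further fall. The step of a 4.0-fold higher number from compound 3 to compound 4 (0.60 log units; beyond the scatter) is expected to point towards weaker inhibition, beyond the scatter. For compound 4 the estimated value is 0.1 nM, with an expected range of 0.02 nM to 0.6 nM.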

Compound 4, half-maximal inhibitory concentration: 0.078 nM
The estimate for compound 4 lay 1.3-fold (0.11 log units) above the measured number; the measured number falls inside the stated range.
By their numbers in this assay, from the lowest: compound 3; then compound 4; then compounds 1 and 2 (each within the scatter of the next).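

Swapping 1-ethyl-1-methylpropyl for ethyl on this aromatic carbon gives the first comparison in this assay that isolates a single change, and the step is modest but beyond the scatter (a 3.1-fold higher number from compound 3 to compound 4 (0.49 log units; beyond the scatter)). Inhibition remains strong with the much smaller chain, as compound 4 gives 0.078 nM and so does not depend on the large branched group. No measurement shown here explains the step. Still open, on these data alone, is how a carboxylic acid, an aminomethyl group or a cyclopropyl ring would behave on this carbon.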